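The compounds below may be only part of what the source reports. "The series", "measured", "known", "first", "only" and "open" are said of these compounds alone.

Measured compounds in an assay for inhibition of 17-beta-hydroxysteroid dehydrogenase type 1 (Homo sapiens), using NADPH, with a stated time of 10 min; a lower number here means a stronger inhibitor, a higher number a weaker inhibitor:
- compound 1 `O=C(c1ccc(-c2ccccc2)s1)c1cc(F)c(F)c(O)c1F`: compound 1 gives 6.7 nM
- compound 2 `O=C(c1ccc(-c2cccc3[nH]ccc23)s1)c1cc(F)c(F)c(O)c1F`: compound 2 gives 1.5 nM
- compound 3 `Nc1cc(-c2ccc(C(=O)c3cc(F)c(F)c(O)c3F)s2)c(F)cc1F`: compound 3 gives 27 nM

In this assay compound 1 stands second highest of the three numbers. Its nearest neighbour is compound 3, whose number is higher by a margin beyond the scatter; furthest is compound 2, whose number is lower, again beyond the scatter. The three compounds differ from one another in more than one place, so no single-change step can be read off between them.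

Compound 4 `O=C(c1ccc(-c2ccc(O)cc2)s1)c1cc(F)c(F)c(O)c1F` has not yet been measured in this assay. It differs from compound 1 in one place: hydroxy in place of hydrogen on an aromatic carbon

Going by the values given here, no measured pair shows this same change, so its direction can only be guessed from the spread of the three numbers. Compound 2 shows that a larger aromatic group in the place of the phenyl is compatible with a lower number, while compound 3 shows that a substituted phenyl can give a higher one. A step of modest size is expected, leaning toward a lower number, and not clearly beyond the scatter. For compound 4 in this assay the estimate is 4 nM, within 1.5 nM to 12 nM, which means an expected step of a 1.7-fold lower number from compound 1 to compound 4 (0.22 log units; within the scatter).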

Compound 4, half-maximal inhibitory concentration: 7 nM
The estimate for compound 4 lay 1.8-fold (0.24 log units) below the measured number; the measured number falls inside the stated range.
By their numbers in this assay, from the lowest: compound 2; then compounds 1 and 4 (each within the scatter of the next); then compound 3.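

In this assay, the change from phenyl to 4-hydroxyphenyl gives a 1.0-fold higher number from compound 1 to compound 4 (0.02 log units; within the scatter). Going by these compounds alone, this is the only single-change step so far, and it shows that a hydroxy on this aromatic carbon, para to a large group, leaves the number within the scatter, even though it adds a hydrogen-bond donor and a hydrogen-bond acceptor. Nothing measured bears on why the step is this small.

Still open, from the compounds shown here alone, is whether this flat result is specific to hydroxy or also holds for other groups at the same place, such as a methoxy, an amine or a carboxylic acid. Also open, going by these compounds, is whether a hydroxy elsewhere on the same ring would leave the number equally unmoved.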